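This account rests on a few compounds, and the source may have more. Where it says the series, first, only, none or still open, it means among the compounds named here.

Working notes on the series. Compound 1 `Cc1ccc(CN2CCC3(CC2)OCCc2sccc23)cc1` in an ADME assay on microsomes from liver (Mus musculus) for metabolic stability, read by LC-MS, using NADPH, with a stated time of 30 min, tested at 0.5 uM (on this read-out higher numbers stand for fast clearance and lower numbers for slow clearance), gives > 30 mL/min/g, a limit of the assay rather than a number. Compound 2 `Cc1ccc(CN2CCC3(CC2)OCCc2sccc23)cc1C` in this assay gives > 30 mL/min/g, again a limit. The step that the two limits leave unreadable from compound 1 to compound 2 is therefore unreadable, since (the limit of > 30 mL/min/g in this assay, at which 2 of the 2 values shown sit). Compound 3 `CC(C)(C)c1ccc(CN2CCC3(CC2)OCCc2sccc23)cc1` differs from compound 1 by tert-butyl in place of methyl on an aromatic carbon. Going by the values given here, no measured step reads out for this change; both known compounds sit at the limit. Compound 3 is expected to stand at 45 mL/min/g, between 25 mL/min/g and 90 mL/min/g, most likely again reported only as a limit. The expected step is a step that the limit leaves unreadable from compound 1 to compound 3.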

Compound 3, intrinsic clearance in a liver preparation (reported as CLH), per the amount of preparation that the assay uses: > 30 mL/min/g
Compound 3: a limit, no number; the forecaster's own chance of this, stated with the estimate: 80%; the middle value is on the limit's open side.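

Compound 3, like compound 1, is reported only as a limit, so no new step can be read between them: the limit of > 30 mL/min/g in this assay, at which 3 of the 3 values shown sit. The compounds shown leave open the actual clearance of compound 1, compound 2 and compound 3, and whether it differs among them at all.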